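Acylating the piperazine nitrogen of compound 1

The source may hold more compounds than are shown below. What is called first, only, known or untested is meant among the compounds shown, and "the series" means these compounds.

In an assay on isolated protein for binding affinity to Melanocortin receptor 4 (Homo sapiens) (a higher number here means a weaker inhibitor, a lower number a stronger inhibitor), compound 1 `CCN1CCN(C(=O)C[C@H](Cc2ccc(Cl)cc2)C(=O)N2CCN(c3ccccc3N(CC3CC3)S(C)(=O)=O)CC2)CC1` gives 9.5 nM, the higher of the two numbers recorded; compound 2 `CS(=O)(=O)N(CC1CC1)c1ccccc1N1CCN(C(=O)[C@H](CC(=O)N2CCN(CC3CC3)CC2)Cc2ccc(Cl)cc2)CC1` gives 3 nM in this assay. Among the compounds with values here, the only step between measured compounds, a 3.2-fold lower number from compound 1 to compound 2 (0.50 log units; beyond the scatter), exchanges methyl for cyclopropyl on a saturated chain carbon bound to an amine nitrogen in a ring.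

Compound 3 `CC(C)(C)CC(=O)N1CCN(C(=O)C[C@H](Cc2ccc(Cl)cc2)C(=O)N2CCN(c3ccccc3N(CC3CC3)S(C)(=O)=O)CC2)CC1` changes the same ring nitrogen, but differently: neopentylcarbonyl in place of ethyl on an amine nitrogen in a ring. The step from compound 1 to compound 2 shows that this position tolerates a larger alkyl group, yet it keeps an alkyl group there, whereas compound 3 places a carbonyl directly on the ring nitrogen. Within the data shown here, no measured pair covers that kind of change, so the recorded step gives only weak guidance, and in this assay the direction for compound 3 is uncertain.

On balance compound 3 is expected to show a modest weakening, a step of a 2.6-fold higher number from compound 1 to compound 3 (0.42 log units; beyond the scatter), with a wide range because the comparison rests on a 3.2-fold lower number from compound 1 to compound 2 (0.50 log units; beyond the scatter) alone. The estimate for compound 3 in this assay is 25 nM, between 5 nM and 120 nM.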

Compound 3, half-maximal inhibitory concentration: < 0.1 nM
Compound 3 was reported as a limit; the forecaster's own chance of this, stated with the estimate: 3%; middle value at least 250-fold (2.39 log units) from the limit.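

In this assay, the ring nitrogen of the shared core accepts a carbonyl as well as an alkyl group: neopentylcarbonyl in place of ethyl gives an at least 95-fold lower number from compound 1 to compound 3 (1.97 log units; beyond the scatter), and neopentylcarbonyl in place of cyclopropylmethyl gives an at least 30-fold lower number from compound 2 to compound 3 (1.47 log units; beyond the scatter). Both of these steps are large, whereas the change within the alkyl groups, a 3.2-fold lower number from compound 1 to compound 2 (0.50 log units; beyond the scatter), is modest, so at this position the swap to neopentylcarbonyl moves the number much further than the swap of one alkyl group for another. The number for compound 3 is a limit of the assay and not a measured value, and the two new steps are limits along with it: the limit of < 0.1 nM in this assay, at which 1 of the 3 values shown sits.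

The compounds shown leave open whether the carbonyl or the neopentyl part accounts for the step, as neopentylcarbonyl enters as a single piece; an acetyl group and a plain neopentyl group on the same ring nitrogen would separate the two. Also open, going by these compounds, is whether a urea or a carbamate at this nitrogen would behave like neopentylcarbonyl.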